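This account rests on a few compounds, and the source may have more. Where it says the series, first, only, none or still open, it means among the compounds named here.

Measured so far in a functional assay on HCT-116 cells (Homo sapiens) for cytotoxicity, read by MTT assay, with a stated time of 48 h; a higher number here means a weaker inhibitor, a lower number a stronger inhibitor:
compound 1 `COc1ccc(NC(=O)c2cn(-c3ccccc3)nc2-c2ccccc2)cc1`: 1350 nM
compound 2 `Cc1ccc(-c2nn(-c3ccccc3)cc2C(=O)Nc2ccccc2)cc1`: 2360 nM

Compound 2 holds the higher of the two numbers. Among the measured compounds shown here, it differs from compound 1 in more than one place, so no single step connects them, and their two values lie within the scatter of each other. Compound 3 `COc1ccc(NC(=O)c2cn(-c3ccccc3)nc2-c2ccc(C)cc2)cc1` has not yet been measured in this assay. Against compound 2 it differs by methoxy in place of hydrogen on an aromatic carbon, so the anilino part of compound 2 becomes (4-methoxyphenyl)amino. For the measured compounds named here, no measured pair isolates this change. Compound 1 carries the same methoxy group and gives 1350 nM, a value within the scatter of compound 2. On that basis the step in this assay is expected to be small, in either direction, and not beyond the scatter. Compound 3 is expected to give 1700 nM (range 700 nM to 4200 nM). This corresponds to an expected step of a 1.4-fold lower number from compound 2 to compound 3 (0.14 log units; within the scatter).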

Compound 3, half-maximal inhibitory concentration: 1450 nM
Estimate against measurement, compound 3: 1.2-fold (0.07 log units) above; the measured number falls inside the stated range.
By their numbers in this assay, from the lowest: compounds 1, 3 and 2 (each within the scatter of the next).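

Among the compounds shown here, compound 3 gives the series its only single-place comparisons in this assay. Methoxy in place of hydrogen on an aromatic carbon, para to a large group, gives a 1.6-fold lower number from compound 2 to compound 3 (0.21 log units; within the scatter), while a methyl group as the one change gives a 1.1-fold higher number from compound 1 to compound 3 (0.03 log units; within the scatter). Both steps lie within the scatter, so neither substitution can be told apart from repeat measurement here, and no supporting measurement bears on either result.

Still open, going by these compounds, is whether any group at these two places gives a step beyond the scatter, for example an amine or a carboxylic acid in place of the methoxy, or a longer chain in place of the methyl. For the compounds shown here, each substitution has also been read on only one matched pair, so neither reading can be extended to other compounds.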